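The source may report more compounds than this note shows. Statements on the series, on what has been measured and on what is new or still open speak of the compounds shown alone.

Among the compounds with values here, compound 2, whose structure is `COc1cc2cc(C(=O)CCc3cc[n+](C)cc3)sc2cc1OC`, stands highest of the two numbers measured so far in a physicochemical assay for solubility (on this read-out lower numbers stand for lower solubility and higher numbers for higher solubility), where compound 2 gives 3000 ug/mL. Its nearest neighbour is compound 1, `COc1cc2cc(C(O)C3CC[N+](C)(Cc4ccccc4)CC3)sc2cc1OC`, and in this assay compound 1 gives 2000 ug/mL, a gap that lies within the scatter of the method. The next compound, compound 3, has the structure `COC(=O)c1ccc(C[n+]2ccc(CCC(=O)c3cc4cc(OC)c(OC)cc4s3)cc2)cc1` and has not yet been measured in this assay. It differs from compound 2 by 4-(methoxycarbonyl)phenyl in place of hydrogen on a saturated chain carbon bound to an aromatic nitrogen. Within the data shown here, no step between measured compounds is on hand to calibrate this change; the two numbers in hand only show that both salts dissolve very readily. Compound 3 is expected to give a lower number than compound 2, with a step of a 3.0-fold lower number from compound 2 to compound 3 (0.48 log units; beyond the scatter) that reaches somewhat beyond the scatter. On that basis compound 3 is estimated at 1000 ug/mL in this assay, within a range from 300 ug/mL to 3000 ug/mL.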

Compound 3, solubility: 3500 ug/mL
Compound 3: the middle estimate sits 3.5-fold (0.54 log units) below what was measured, and the stated range ends below it.
By their numbers in this assay, from the lowest: compounds 1, 2 and 3 (each within the scatter of the next).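

In this assay this place, a saturated chain carbon bound to an aromatic nitrogen, now has its first readable step: 4-(methoxycarbonyl)phenyl in place of hydrogen gives a 1.2-fold higher number from compound 2 to compound 3 (0.07 log units; within the scatter) and so leaves compound 3 level with compound 2. Within the data shown here, the entering group brings 10 heavy atoms and one six-membered aromatic ring, and the read-out still shows no difference beyond the scatter, which the two earlier compounds could not show, as they offered no step at this place. Nothing measured on these compounds offers a reason for this outcome. Open, from the compounds shown here alone, is whether a plain phenyl, or a carboxylic acid in place of the methyl ester, would also stay within the scatter of compound 2. Also open, going by these compounds, is whether an amine or a longer chain at this same place would do so.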